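Trading a Carboxylic Acid for a Methylamide on a Shared Core

The compounds below may be only part of what the source reports. "The series", "measured", "known", "first", "only" and "open" are said of these compounds alone.

Compound 1 `CC(C)[C@H]1CC[C@@]2(CO2)[C@H]2C(=O)OCC(C(=O)OCc3ccc(-c4ccccc4)o3)=C[C@H]12` and compound 2 `CC(C)[C@H]1CC[C@@]2(CO2)[C@H]2C(=O)OCC(C(=O)O)=C[C@H]12` share the same core and were both tested in a functional assay on WM 266-4 cells (Homo sapiens) for inhibition, with a stated time of 72 h; on this read-out lower numbers stand for stronger inhibition and higher numbers for weaker inhibition. In that setting compound 1 gives 960 nM, and compound 2 gives 509 nM. Compound 2 carries the lowest of the two numbers, but its gap to compound 1 lies within the usual scatter of repeated measurements, so the two cannot be told apart on these numbers. Compound 3 `CNC(=O)C1=C[C@@H]2[C@@H](C(C)C)CC[C@@]3(CO3)[C@H]2C(=O)OC1` is built from compound 2 by a single change: methylamino in place of hydroxy on a carbonyl carbon. Among the measured compounds shown here, no pair of measured compounds shows this change, so its effect cannot be read off from the data. The step expected here is a 1.2-fold higher number from compound 2 to compound 3 (0.07 log units; within the scatter), no larger than the scatter in either direction. Compound 3 is therefore estimated to give about 600 nM in this assay, within a range from 200 nM to 2000 nM.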

Compound 3, half-maximal inhibitory concentration: 5900 nM
The estimate for compound 3 lay 9.8-fold (0.99 log units) below the measured number; measured number above the stated range.
By their numbers in this assay, from the lowest: compounds 2 and 1 (each within the scatter of the next); then compound 3.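

Among the compounds shown here, putting methylamino in place of hydroxy on this carbonyl carbon weakens inhibition clearly in this assay, with a 12-fold higher number from compound 2 to compound 3 (1.06 log units; beyond the scatter), the first single change at this position for which a step can be read. The position is therefore sensitive to what sits on the carbonyl carbon, even though hydroxy and methylamino are counted alike for hydrogen-bond donors, acceptors and net charge. Nothing measured here accounts for this loss of inhibition.

From the compounds shown here alone, what remains open is whether the loss follows from the nitrogen itself or from its added methyl group. A plain amino group on the same carbonyl carbon would help separate these two, while a dimethylamino or ethylamino group would show how the number responds as the group on the nitrogen grows.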